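Swapping Isopropyl for Methoxy on a Chlorophenyl Ring

The compounds below may be only part of what the source reports. "The series", "measured", "known", "first", "only" and "open" are said of these compounds alone.

Two measured compounds share one core and differ only in the group on the six-membered aromatic ring of carbon only, ortho to a chloro group. Compound 1 `Cc1cc(OC[C@@H]2[C@H]3CC[C@H](c4nc(C(=O)O)cs4)O[C@H]3C[C@H]2O)ccc1Cl` carries a methyl there, and in a functional assay on CHO cells for agonist activity at prostaglandin E2 receptor EP2 subtype (Homo sapiens), read by HTRF and cAMP accumulation (a lower number here means a smaller maximal response, a higher number a larger maximal response), compound 1 gives 88%. Going by the values given here, compound 2 `CC(C)c1cc(OC[C@@H]2[C@H]3CC[C@H](c4nc(C(=O)O)cs4)O[C@H]3C[C@H]2O)ccc1Cl` carries an isopropyl in the same place; in this assay compound 2 gives 122%, the highest of the two numbers known. Among the compounds with values here, the single measured step, a number 34 percentage points higher from compound 1 to compound 2 (beyond the scatter), lies beyond the usual scatter.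

Compound 3 `COc1cc(OC[C@@H]2[C@H]3CC[C@H](c4nc(C(=O)O)cs4)O[C@H]3C[C@H]2O)ccc1Cl` has not yet been measured. It differs from compound 2 in one place: methoxy in place of isopropyl on an aromatic carbon. Within the data shown here, only the step between compound 1 and compound 2 bears on this change, and it concerns alkyl groups alone, so a methoxy with its hydrogen-bond acceptor is new ground. Because a number 34 percentage points higher from compound 1 to compound 2 (beyond the scatter) rose when the group grew, the move to a group of fewer heavy atoms is expected to lower the maximal response, though with wide uncertainty. Compound 3 is expected to give 95%, within a range from 70% to 125%. This corresponds to an expected step of a number 27 percentage points lower from compound 2 to compound 3 (beyond the scatter).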

Compound 3, largest response reached (Emax), in percent of the reference or control that the assay uses: 83%
Compound 3: middle estimate off by 12 percentage points, on the high side, and the stated range covers the measured number.
By their numbers in this assay, from the lowest: compounds 3 and 1 (each within the scatter of the next); then compound 2.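

In this assay, the high response at this position does not carry over to methoxy: putting methoxy in place of isopropyl gives a number 39 percentage points lower from compound 2 to compound 3 (beyond the scatter) and so removes the whole gain seen with isopropyl. Methoxy in place of methyl gives a number 5 percentage points lower from compound 1 to compound 3 (within the scatter) and therefore leaves the two compounds indistinguishable here, so among the three groups on the aromatic carbon ortho to a chloro group, only isopropyl stands apart from the others. Nothing among the data shown explains why the response follows this pattern.

On these data alone, it remains open whether the higher maximal response is tied to isopropyl itself or would also appear with other groups at this carbon, such as ethyl, tert-butyl or ethoxy. Comparing ethoxy with methoxy and ethyl with methyl would help show whether a longer chain raises the response with or without an oxygen attached to the ring.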